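The compounds below may be only part of what the source reports. "The series", "measured", "known", "first", "only" and "open" are said of these compounds alone.

Measured in a functional assay on HepG2 cells (Homo sapiens) for inhibition, read by MTT assay, with a stated time of 72 h; on this read-out higher numbers stand for weaker inhibition and lower numbers for stronger inhibition:
compound 1 `CN(C(=O)NC(=O)c1cccc(C(F)(F)F)c1)c1nc(C(F)(F)F)c(C(=O)N/N=C/c2ccccc2C(F)(F)F)s1` gives 10.4 ug/mL
compound 2 `CN(C(=O)NC(=O)c1ccc(F)c(F)c1)c1nc(C(F)(F)F)c(C(=O)N/N=C/c2ccccc2C(F)(F)F)s1` gives 10.4 ug/mL
compound 3 `CN(C(=O)NC(=O)c1ccc(Cl)cc1Cl)c1nc(C(F)(F)F)c(C(=O)N/N=C/c2ccccc2C(F)(F)F)s1` gives 10.7 ug/mL

Compound 3 stands indistinguishably beside the other two on this read-out: the steps of a 1.0-fold higher number from compound 1 to compound 3 (0.01 log units; within the scatter) and a 1.0-fold higher number from compound 2 to compound 3 (0.01 log units; within the scatter) both lie inside the scatter, so no ranking among compound 1, compound 2 and compound 3 can be drawn from the numbers shown.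

Compound 4 `CN(C(=O)NC(=O)c1c(Cl)cccc1Cl)c1nc(C(F)(F)F)c(C(=O)N/N=C/c2ccccc2C(F)(F)F)s1` is the next member. It differs from compound 3 only by 2,6-dichlorophenyl in place of 2,4-dichlorophenyl on a carbonyl carbon. The measured steps that bear on this change are those that also exchange the aryl group on the carbonyl carbon: no change at the digits printed from compound 1 to compound 2 (within the scatter), a 1.0-fold higher number from compound 1 to compound 3 (0.01 log units; within the scatter) and a 1.0-fold higher number from compound 2 to compound 3 (0.01 log units; within the scatter). None of them moved the number beyond the scatter, with three different aryl groups tried at that place. A further exchange of one dichlorophenyl for another at the same carbonyl carbon is thus expected to give no step beyond the scatter, the expected step being a 1.0-fold lower number from compound 3 to compound 4 (0.00 log units; within the scatter). Compound 4 is estimated at 10.6 ug/mL, with a range from 6 ug/mL to 19 ug/mL.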

Compound 4, half-maximal inhibitory concentration: 8.95 ug/mL
Beside the measured number, compound 4's estimate is 1.2-fold (0.07 log units) above it, within the range that was stated.
By their numbers in this assay, from the lowest: compounds 4, 1, 2 and 3 (each within the scatter of the next).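

In this assay, exchanging 2,4-dichlorophenyl for 2,6-dichlorophenyl on the carbonyl carbon, with the same atoms joined differently, gives a 1.2-fold lower number from compound 3 to compound 4 (0.08 log units; within the scatter). The comparisons with the other two aryl groups give a 1.2-fold lower number from compound 2 to compound 4 (0.07 log units; within the scatter) and a 1.2-fold lower number from compound 1 to compound 4 (0.07 log units; within the scatter), so all four aryl groups shown at this place lie within the scatter of one another. No information is available to account for this flat result.

Every group shown at this carbonyl carbon is a phenyl ring bearing chlorine, fluorine or trifluoromethyl, so it remains open whether an amine, a carboxylic acid or a longer alkyl chain there would shift the number. On these data alone, the rest of the shared core is identical in all four compounds, so the effect of changes elsewhere also remains open.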